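Moving the pyridine nitrogen: from compound 2 to compound 3

The source may hold more compounds than are shown below. What is called first, only, known or untested is meant among the compounds shown, and "the series" means these compounds.

Measured compounds:
compound 1 `NS(=O)(=O)Oc1ccc2c(c1)CN(C(=O)c1cccc(N3CCCCC3)c1)CC2` — 11.9%
compound 2 `CCN(Cc1cccnc1)c1cccc(C(=O)N2CCc3ccc(OS(N)(=O)=O)cc3C2)c1` — 33.5%

In an assay on HEK293 cells for inhibition of Steryl-sulfatase (Homo sapiens), tested at 1 uM (a higher number here means a stronger effect of the compound at the concentration tested, a lower number a weaker effect), compound 1 gives 11.9%, while compound 2 gives 33.5%. Going by the values given here, compound 2 stands highest of the two numbers; its only neighbour is compound 1, and the step of a number 21.6 percentage points higher from compound 1 to compound 2 (beyond the scatter) separates them. Compound 3 `CCN(Cc1ccccn1)c1cccc(C(=O)N2CCc3ccc(OS(N)(=O)=O)cc3C2)c1` shares the whole core of compound 2 and differs from it only in one place: pyridin-2-yl in place of pyridin-3-yl on a saturated chain carbon bound to a nitrogen on an aromatic ring. Among the compounds with values here, the single measured step, a number 21.6 percentage points higher from compound 1 to compound 2 (beyond the scatter), concerns a different change, the exchange of a whole ring on the aromatic carbon, so no measured step bears on shifting the nitrogen inside the ring. Without any step of this kind to lean on, the safest reading is that such a rearrangement of the same atoms leaves the percentage roughly where compound 2 sits. The expected step is therefore a number 3.5 percentage points lower from compound 2 to compound 3 (within the scatter), which lies within the usual scatter. Compound 3 is thus estimated at 30%, with a range from 12% to 50%, the width reflecting the lack of a guiding step.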

Compound 3, a percentage reported as inhibition, at one concentration (the size of the read-out at that concentration, not a potency): 19.9%
Compound 3: the middle estimate sits 10.1 percentage points above what was measured; measured number inside the range.
By their numbers in this assay, from the lowest: compounds 1 and 3 (each within the scatter of the next); then compound 2.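

Within this assay, the place of the nitrogen inside the pyridine ring matters even though no atom is added or removed: pyridin-2-yl in place of pyridin-3-yl gives a number 13.6 percentage points lower from compound 2 to compound 3 (beyond the scatter), a change that the earlier pair could not reveal. The rise seen earlier with ethyl((pyridin-3-yl)methyl)amino therefore does not carry over to every pyridine version of this side group: ethyl((pyridin-2-yl)methyl)amino in place of piperidin-1-yl gives only a number 8 percentage points higher from compound 1 to compound 3 (within the scatter), so on this read-out compound 3 cannot be told apart from compound 1. Nothing available explains why these two arrangements of the same atoms differ.

Going by these compounds, what remains open is whether pyridin-4-yl on the same saturated chain carbon would keep the number near that of compound 2 or bring it closer to that of compound 3, and whether a plain phenyl ring there would do either. It is also unclear how much the ethyl group contributes, and a methyl or propyl group in its place would test that.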